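The source may hold more compounds than are shown below. What is called first, only, known or untested is meant among the compounds shown, and "the series" means these compounds.

Measured compounds:
- compound 1, `Brc1ccc(NCc2nc3ccc(Br)cc3[nH]2)cc1`: 23.5%
- compound 2, `c1ccc(NCc2nc3ccccc3[nH]2)cc1`: 41.1%
- compound 3, `Brc1ccc2nc(CNc3ccccc3)[nH]c2c1`: 29.4%

In a functional assay on the whole organism (strain albino) for inhibition, with Rattus norvegicus as the target, read by paw edema, with a stated time of 120 min, at a dose of 100 mg/kg by the oral route (a lower number here means less inhibition, a higher number more inhibition at the dose given (going by the name of the read-out)), compound 2 gives the highest of the three numbers, with compound 3 nearest and compound 1 furthest, both beyond the scatter. The unmeasured compound 4, `Brc1ccc(NCc2nc3ccccc3[nH]2)cc1`, differs from compound 2 in one place: bromo in place of hydrogen on an aromatic carbon.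

Among the compounds with values here, two measured steps bear on this change. The step of a number 5.9 percentage points higher from compound 1 to compound 3 (within the scatter) is the same change run backwards, on the same ring of carbon only, and it lies within the scatter. The step of a number 11.7 percentage points lower from compound 2 to compound 3 (beyond the scatter) concerns a bromo entering on the other ring of the shared core and gives a modest loss beyond the scatter. Since the step that matches the change to compound 4 in its place is the one within the scatter, and the loss seen in a number 11.7 percentage points lower from compound 2 to compound 3 (beyond the scatter) belongs to a different place, the expectation for compound 4 is a small step downward, of a size that stays within the scatter, a number 5.1 percentage points lower from compound 2 to compound 4 (within the scatter).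

Compound 4 is therefore estimated to give 36% in this assay, with a range from 26% to 46%.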

Compound 4, a percentage reported as inhibition, in the whole organism at one dose (the size of the read-out at that dose, not a potency): 23.5%
Beside the measured number, compound 4's estimate is 12.5 percentage points above it; measured number below the stated range.
By their numbers in this assay, from the lowest: compounds 1, 4 and 3 (each within the scatter of the next); then compound 2.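

In this assay, the bromo para to a large group on the six-membered aromatic ring of carbon only now has a step beyond the scatter on the core without a second bromo, a number 17.6 percentage points lower from compound 2 to compound 4 (beyond the scatter), whereas the earlier compounds had shown this place only on the core of compound 1, within the scatter. The size of the change at this place still cannot be said to depend on the core, as the two readings do not stand apart: the same change on two cores in this assay, a number 5.9 percentage points higher (within the scatter) from compound 1 to compound 3 and a number 17.6 percentage points higher (beyond the scatter) from compound 4 to compound 2, 11.7 percentage points apart, within the scatter of two such steps

The result also shows that, with this bromo present, the bromo on the shared core makes no visible difference, no change at the digits printed from compound 1 to compound 4 (within the scatter), although that same bromo alone had given a step beyond the scatter from compound 2; these two readings do not stand apart either: the same change on two cores in this assay, a number 11.7 percentage points lower (beyond the scatter) from compound 2 to compound 3 and no change at the digits printed (within the scatter) from compound 4 to compound 1, 11.7 percentage points apart, within the scatter of two such steps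

The compounds shown leave open whether the step at this place belongs to bromo in particular or would also appear with a chloro, a methoxy or an amine on the same aromatic carbon. They also leave open what a carboxylic acid there would do, and whether the step would hold at any other dose.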